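Aryl swap on the sulfonyl of the piperazine series

The compounds below may be only part of what the source reports. "The series", "measured", "known", "first", "only" and "open" are said of these compounds alone.

Compound 1 `COc1cc2nc(N3CCN(C(=O)OCc4ccccc4)CC3)nc(N)c2cc1OC` gives 63000 nM in a functional assay on PC-3 cells (Homo sapiens) for inhibition; on this read-out lower numbers stand for stronger inhibition and higher numbers for weaker inhibition. Compound 2 `COc1cc2nc(N3CCN(S(=O)(=O)c4ccc(I)cc4)CC3)nc(N)c2cc1OC` gives 15000 nM in this assay, and compound 3 `COc1cc2nc(N3CCN(S(=O)(=O)c4ccc(Cl)s4)CC3)nc(N)c2cc1OC` gives 25000 nM in this assay; compound 3 thus stands second highest of the three numbers, with a 2.5-fold lower number from compound 1 to compound 3 (0.40 log units; beyond the scatter) and a 1.7-fold higher number from compound 2 to compound 3 (0.22 log units; within the scatter). Compound 4 `COc1cc2nc(N3CCN(S(=O)(=O)c4cccc([N+](=O)[O-])c4)CC3)nc(N)c2cc1OC` carries 3-nitrophenyl in place of 5-chlorothiophen-2-yl on a sulfonyl sulfur. Among the measured compounds shown here, only the step between compound 2 and compound 3 bears directly on exchanging the aryl group on the sulfonyl sulfur, and that step lay within the scatter; a 4.2-fold lower number from compound 1 to compound 2 (0.62 log units; beyond the scatter) and a 2.5-fold lower number from compound 1 to compound 3 (0.40 log units; beyond the scatter) concern the sulfonyl replacing benzyloxycarbonyl and do not speak to this swap. The expected step in this assay is therefore a 1.3-fold lower number from compound 3 to compound 4 (0.10 log units; within the scatter), nothing beyond the scatter. Compound 4 is estimated at 20000 nM, range 7000 nM to 60000 nM.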

Compound 4, half-maximal inhibitory concentration: 32000 nM
Estimate against measurement, compound 4: 1.6-fold (0.20 log units) below; the range from low to high includes it.
By their numbers in this assay, from the lowest: compounds 2, 3, 4 and 1 (each within the scatter of the next, the first and the last beyond it).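

In this assay, the sulfonyl sulfur accepts 3-nitrophenyl in place of 5-chlorothiophen-2-yl with little effect, giving a 1.3-fold higher number from compound 3 to compound 4 (0.11 log units; within the scatter) and extending the tolerated groups to a nitro-bearing phenyl. Among the compounds shown here, in contrast, replacing 4-iodophenyl with 3-nitrophenyl gives a 2.1-fold higher number from compound 2 to compound 4 (0.33 log units; beyond the scatter), the first aryl exchange at this position to exceed the scatter, though only modestly. Across compound 2, compound 3 and compound 4, this position has therefore shown only small changes.

From the compounds shown here alone, whether an amine or a carboxylic acid on the phenyl ring, or a longer alkyl chain on the sulfonyl sulfur, would shift the number more remains open. Nothing available explains the small gap between 4-iodophenyl and 3-nitrophenyl.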